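Lengthening the hydroxamate chain of compound 3 by one carbon

This account rests on a few compounds, and the source may have more. Where it says the series, first, only, none or still open, it means among the compounds named here.

Three compounds with a shared core carrying a hydroxamic acid at the end of a chain have been measured. In an assay on isolated protein for inhibition of Nicotinamide phosphoribosyltransferase (Homo sapiens), read by fluorescence, with stated times of 5 min and 15 min (a lower number here means a stronger inhibitor, a higher number a weaker inhibitor), compound 3 `O=C(CCCCCN(Cc1ccc(F)cc1)c1ncc(C(=O)NCCCn2ccnc2)s1)NO` gives 7 nM, the lowest of the three numbers. In this assay compound 1 `O=C(CCCCCCCN(Cc1ccc(F)cc1)c1ncc(C(=O)NCCCn2ccnc2)s1)NO` gives 18 nM, and compound 2 `CC(C)CCN(CCCCCC(=O)NO)c1ncc(C(=O)NCCCn2ccnc2)s1` gives 20 nM. The step of a 2.6-fold lower number from compound 1 to compound 3 (0.41 log units; beyond the scatter) shortens the chain that carries the hydroxamic acid and is the one that bears directly on the present question. The step of a 2.9-fold lower number from compound 2 to compound 3 (0.46 log units; beyond the scatter) changes a different part of the molecule and says little about chain length.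

Compound 4 `O=C(CCCCCCN(Cc1ccc(F)cc1)c1ncc(C(=O)NCCCn2ccnc2)s1)NO` differs from compound 3 by (hydroxycarbamoyl)methyl in place of hydroxycarbamoyl on a saturated chain carbon, five bonds along the chain from a nitrogen on an aromatic ring. Its chain is thus longer than that of compound 3 and shorter than that of compound 1, so compound 4 is expected to fall between those two values, because a 2.6-fold lower number from compound 1 to compound 3 (0.41 log units; beyond the scatter) covers the whole span of which this is one part. The step of a 1.6-fold higher number from compound 3 to compound 4 (0.20 log units; within the scatter) is therefore expected to be small, probably within the usual scatter or slightly toward a higher number. For compound 4 the estimate is 11 nM, with a range from 5 nM to 25 nM.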

Compound 4, half-maximal inhibitory concentration: 19 nM
Beside the measured number, compound 4's estimate is 1.7-fold (0.24 log units) below it; measured number inside the range.
By their numbers in this assay, from the lowest: compound 3; then compounds 1, 4 and 2 (each within the scatter of the next).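

In this assay the extension by one carbon proves to be the step that matters: the step of a 2.7-fold higher number from compound 3 to compound 4 (0.43 log units; beyond the scatter) is beyond the scatter. It is about as large as the whole span, the step of a 2.6-fold lower number from compound 1 to compound 3 (0.41 log units; beyond the scatter), while the step of a 1.1-fold higher number from compound 1 to compound 4 (0.02 log units; within the scatter) stays within the scatter. Among these three chains, then, the number does not rise gradually with length: replacing hydroxycarbamoyl with (hydroxycarbamoyl)methyl accounts for the difference, and the further carbon in compound 1 brings no change that can be told from scatter, so compound 4 and compound 1 cannot be ordered. No evidence is at hand to explain why the number behaves this way at this position.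

The compounds shown leave open whether a shorter chain than that of compound 3 would give a lower number still, or whether a longer chain than that of compound 1 would stay level with compound 1 and compound 4. They also leave open whether the shortest chain's advantage depends on the hydroxamic acid, since a carboxylic acid at the chain end does not appear among them.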